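The source may report more compounds than this note shows. Statements on the series, on what has been measured and on what is new or still open speak of the compounds shown alone.

In an ADME assay on L6 cells (Rattus norvegicus) for cytotoxicity, read by resazurin assay, with a stated time of 72 h (on this read-out higher numbers stand for weaker inhibition and lower numbers for stronger inhibition), compound 1 `Cc1ccc(/C=N/N=C(\N)CC(O)c2cccc3ccccc23)cc1` gives 6800 nM, compound 2 `N/C(CC(O)c1cccc2ccccc12)=N\N=C\c1cccnc1` gives 22000 nM, and compound 3 `C/C(=N\N=C(/N)CC(O)c1cccc2ccccc12)c1ccc(F)cc1` gives 34000 nM. Compound 2 thus holds the second highest of the three numbers: its gap to compound 3 lies within the scatter, while the step of a 3.2-fold higher number from compound 1 to compound 2 (0.51 log units; beyond the scatter) lies beyond it. Compound 4 `N/C(CC(O)c1cccc2ccccc12)=N\N=C\c1cccc(Br)c1` differs from compound 2 by 3-bromophenyl in place of pyridin-3-yl on a carbon with a double bond to nitrogen. Going by the values given here, the only measured step touching this position is a 3.2-fold higher number from compound 1 to compound 2 (0.51 log units; beyond the scatter), where a carbon-only ring was exchanged for pyridin-3-yl and the number rose. Since compound 4 returns a carbon-only ring at that place, a lowering of the number is expected, estimated as a 2.4-fold lower number from compound 2 to compound 4 (0.39 log units; beyond the scatter). Compound 4 is therefore expected to give about 9000 nM in this assay, within 3500 nM to 25000 nM.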

Compound 4, half-maximal inhibitory concentration: 3900 nM
Compound 4: the middle estimate sits 2.3-fold (0.36 log units) above what was measured, and the stated range covers the measured number.
By their numbers in this assay, from the lowest: compounds 4 and 1 (each within the scatter of the next); then compounds 2 and 3 (each within the scatter of the next).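

In this assay the step of a 5.6-fold lower number from compound 2 to compound 4 (0.75 log units; beyond the scatter) shows that a second carbon-only ring, here 3-bromophenyl, also goes with a lower number than pyridin-3-yl on a carbon with a double bond to nitrogen. The step of a 1.7-fold lower number from compound 1 to compound 4 (0.24 log units; within the scatter) sets no order between 3-bromophenyl and 4-methylphenyl. Nothing measured here explains the gap between these carbon-only rings and pyridin-3-yl. From the compounds shown here alone, whether the number follows the ring nitrogen of pyridin-3-yl or the bromine of 3-bromophenyl stays open, as does where a ring bearing an amine or a carboxylic acid would fall.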